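Quinazoline amide series: acrylamide tail change toward compound 4

This account rests on a few compounds, and the source may have more. Where it says the series, first, only, none or still open, it means among the compounds named here.

Measured compounds:
Compound 1, `CC(C)=CC(=O)Nc1cc2c(N3CCc4ccccc43)ncnc2cc1O[C@@H]1CCOC1`, 4620 nM in a functional assay on PC-3 cells (Homo sapiens) for antiproliferative activity, read by MTT assay, with a stated time of 72 h; a higher number here means a weaker inhibitor, a lower number a stronger inhibitor
Compound 2, `CC/C=C/C(=O)Nc1cc2c(N3CCCc4ccccc43)ncnc2cc1OC`, 6310 nM in this assay
Compound 3, `CC/C=C/C(=O)Nc1cc2c(N3CCCc4ccccc43)ncnc2cc1O[C@@H]1CCOC1`, 14300 nM in this assay

Compound 2 stands second highest of the three numbers in this assay. Its nearest neighbour is compound 1, whose number sits within the scatter of that of compound 2, so no order between these two is claimed. For the measured compounds named here, the one step that is resolved runs from compound 2 to compound 3: a 2.3-fold higher number from compound 2 to compound 3 (0.36 log units; beyond the scatter), a modest change that lies at the oxygen on the aromatic ring and not at the amide side chain.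

Compound 4, `COc1cc2ncnc(N3CCCc4ccccc43)c2cc1NC(=O)/C=C/CN1CCC(CO)CC1`, is the next target in this assay. It differs from compound 2 only at the amide tail: 4-(hydroxymethyl)piperidin-1-yl in place of methyl on a saturated chain carbon bound to a double-bonded chain carbon. Going by the values given here, no measured pair in this small set alters the amide tail, so the single resolved step, between compound 2 and compound 3, concerns another site and offers no direct guide. With nothing to anchor the direction, the expectation for compound 4 is a number close to that of compound 2, with any shift plausibly within or only slightly beyond the scatter, expressed as a 1.6-fold lower number from compound 2 to compound 4 (0.20 log units; within the scatter). The estimate for compound 4 in this assay is therefore 4000 nM, with a range from 1500 nM to 12000 nM.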

Compound 4, half-maximal inhibitory concentration: 7150 nM
The estimate for compound 4 lay 1.8-fold (0.25 log units) below the measured number, and the stated range covers the measured number.
By their numbers in this assay, from the lowest: compounds 1, 2, 4 and 3 (each within the scatter of the next, the first and the last beyond it).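

For the compounds shown here, the amide tail is read here for the first time: in this assay, a 1.1-fold higher number from compound 2 to compound 4 (0.05 log units; within the scatter), so 4-(hydroxymethyl)piperidin-1-yl in place of methyl on a saturated chain carbon bound to a double-bonded chain carbon gives a number that cannot be told apart from that of the parent. Going by these compounds alone, on this single pair, the position carries a far larger group, with a six-membered non-aromatic ring and a hydrogen-bond donor, without a resolved step, whereas the only resolved step so far, a 2.3-fold higher number from compound 2 to compound 3 (0.36 log units; beyond the scatter), lies at the oxygen on the aromatic ring. Nothing at hand accounts for why the numbers of this pair sit so close together.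

One pair cannot show whether this tolerance extends to the tail in general, and plain piperidin-1-yl, morpholin-4-yl, dimethylamino, a carboxylic acid or a longer chain at the same place would each test that further. Within the data shown here, also open is whether the 4-(hydroxymethyl)piperidin-1-yl tail reads the same with oxolan-3-yl in place of methyl on the oxygen on the aromatic ring, since no pair here varies both sites.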